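Amide to Urea on a Shared Core: Expected Inhibition

A few compounds are considered here, and "the series" means these few. Any claim that something is new, unique, unknown or untested is made for them only; others in the source may bear on it.

Measured compounds:
compound 1 `COc1ccc(C(=O)Nc2nn(-c3ccccc3)c(=O)c3ccccc23)cc1`: 0%
compound 2 `O=C(Nc1nn(-c2ccccc2)c(=O)c2ccccc12)c1ccc(Cl)cc1`: 26%
compound 3 `Nc1nn(-c2ccccc2)c(=O)c2ccccc12`: 24%

In an assay on CHO cells for displacement of a labelled ligand from adenosine receptor A1 (Homo sapiens), tested at 10 uM (a higher number here means more inhibition at the concentration tested (going by the name of the read-out), a lower number less inhibition), compound 1 gives 0%, the lowest of the three numbers; compound 3 stands nearest to it at 24%, and compound 2 furthest at 26%. Compound 4 `Cc1ccccc1NC(=O)Nc1nn(-c2ccccc2)c(=O)c2ccccc12` is not yet measured. It differs from compound 1 by (2-methylphenyl)amino in place of 4-methoxyphenyl on a carbonyl carbon.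

Two measured steps exist. One exchanges a substituent on the aromatic ring of the amide: a number 26 percentage points higher from compound 1 to compound 2 (beyond the scatter). The other removes the whole acyl group: a number 2 percentage points lower from compound 2 to compound 3 (within the scatter). Neither touches the carbonyl carbon itself, so neither bears directly on the change to a urea. Together they show that the amide portion can be altered while the numbers of compound 2 and compound 3 stay level with each other, whereas the number of the methoxy-bearing compound 1 is lower than both. A modest rise towards the level of compound 2 and compound 3 is therefore expected, but with wide uncertainty.

Compound 4 is thus estimated at 18%, from 0% to 40%. The estimated step is a number 18 percentage points higher from compound 1 to compound 4 (beyond the scatter).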

Compound 4, a percentage reported as inhibition, at one concentration (the size of the read-out at that concentration, not a potency): 20%
Compound 4: middle estimate off by 2 percentage points, on the low side; the range from low to high includes it.
By their numbers in this assay, from the lowest: compound 1; then compounds 4, 3 and 2 (each within the scatter of the next).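

In this assay, for the compounds shown here, the result is the first reading of a change at the carbonyl carbon itself, where (2-methylphenyl)amino in place of 4-methoxyphenyl gives a number 20 percentage points higher from compound 1 to compound 4 (beyond the scatter) in a step beyond the scatter. Against the chloro amide, the same position gives a number 6 percentage points lower from compound 2 to compound 4 (within the scatter) and so places the urea compound 4 level with compound 2, which shows that an amide and a urea on the shared core can read alike in this assay. Nothing measured here accounts for either step.

The compounds shown leave open how much of the reading belongs to the urea link and how much to the 2-methylphenyl group. They also leave open how a urea bearing a plain phenyl, a 4-methoxyphenyl or a cyclohexyl group would read at this position.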